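Changing the phenyl group on the ether oxygen

This account rests on a few compounds, and the source may have more. Where it says the series, first, only, none or still open, it means among the compounds named here.

Compound 3 `Cc1nn(C)c(Oc2ccc(I)cc2)c1/C=N\CCCCCCOc1cc2oc(=O)cc(C)c2cc1Cl` is tested in a functional assay on HepG2 cells (Homo sapiens) for antiproliferative activity, read by MTT assay, with a stated time of 72 h (a lower number here means a stronger inhibitor, a higher number a weaker inhibitor), where compound 3 gives 14200 nM. Among the two numbers known, compound 3 stands highest; its nearest neighbour is compound 2 `Cc1nn(C)c(Oc2ccc(Cl)cc2)c1/C=N\CCCCCCOc1cc2oc(=O)cc(C)c2cc1Cl`, which in this assay gives 2960 nM, and the measured step is a 4.8-fold higher number from compound 2 to compound 3 (0.68 log units; beyond the scatter). Compound 1 `Cc1nn(C)c(Oc2ccccc2F)c1/C=N\CCCCCCOc1cc2oc(=O)cc(C)c2cc1Cl` reaches only a limit of the assay, > 25000 nM (the limit of > 25000 nM in this assay, at which 1 of the 3 values shown sits). Compound 4 `Cc1nn(C)c(Oc2cccc(C(F)(F)F)c2)c1/C=N\CCCCCCOc1cc2oc(=O)cc(C)c2cc1Cl` is not yet measured; it differs from compound 3 in that (3-(trifluoromethyl)phenyl in place of 4-iodophenyl on an oxygen on an aromatic ring). The measured steps touching this part of the molecule are an at least 8.4-fold lower number from compound 1 to compound 2 (0.92 log units; beyond the scatter) and an at least 1.7-fold lower number from compound 1 to compound 3 (0.24 log units; that floor lies within the scatter), both changing the substituent on the same ring, but none involves a trifluoromethyl group, so the direction is uncertain. The expected step is a 1.8-fold lower number from compound 3 to compound 4 (0.25 log units; within the scatter). Compound 4 is estimated at 8000 nM, within a range from 2500 nM to 25000 nM.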

Compound 4, half-maximal inhibitory concentration: > 25000 nM
Compound 4: a limit, no number (the forecaster's own chance of this, stated with the estimate: 25%); at least 3.1-fold (0.49 log units) between middle value and limit.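

Compound 4 gives a limit, not a number: the limit of > 25000 nM in this assay, at which 2 of the 4 values shown sit.

The 4-chlorophenyl group stays clearly ahead of the new group, with an at least 8.4-fold higher number from compound 2 to compound 4 (0.92 log units; beyond the scatter), whereas the comparison with 4-iodophenyl gives only an at least 1.7-fold higher number from compound 3 to compound 4 (0.24 log units; that floor lies within the scatter). Among the compounds shown, only the 4-chlorophenyl and 4-iodophenyl groups give numbers; the step between compound 1 and compound 4 cannot be read, as both are limits.

As far as these compounds go, whether the trifluoromethyl group itself or its place on the ring matters remains open. So does how an unsubstituted phenyl or a 4-aminophenyl group on the oxygen would compare.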